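The compounds below may be only part of what the source reports. "The series", "measured", "known", "first", "only" and "open" are said of these compounds alone.

Compound 1 `COC(=O)c1cccc(OC(c2ccc(C(F)(F)F)cc2)C2CCN(C(C)CCNC(=O)c3c(Cl)cncc3Cl)CC2)n1` gives 14600 nM in an ADME assay on PBMC cells (Homo sapiens) for cytotoxicity; a lower number here means that less compound is tolerated, a higher number that more compound is tolerated.
Compound 2 `CC(CCNC(=O)c1c(Cl)cncc1Cl)N1CCC(C(Oc2cccc(C#N)n2)c2ccc(C(F)(F)F)cc2)CC1` gives 15700 nM in this assay.
Compound 3 `CC(CCNC(=O)c1c(Cl)cncc1Cl)N1CCC(C(Oc2cccc(F)c2)c2ccc(C(F)(F)F)cc2)CC1` gives 5400 nM in this assay.

Compound 3 stands lowest of the three in this assay; its gaps to compound 1 and to compound 2 lie beyond the scatter. Compound 4 `COC(=O)c1cccc(OC(c2ccc(C(F)(F)F)cc2)C2CCN(C(C)CCNC(=O)c3c(Cl)cncc3Cl)CC2)c1` differs from compound 3 by methoxycarbonyl in place of fluoro on an aromatic carbon. Among the compounds with values here, the steps that bear on this are a 2.7-fold lower number from compound 1 to compound 3 (0.43 log units; beyond the scatter) and a 2.9-fold lower number from compound 2 to compound 3 (0.46 log units; beyond the scatter), though each of them also exchanges the ring itself, so they overlap only partly with the present change; a 1.1-fold higher number from compound 1 to compound 2 (0.03 log units; within the scatter) shows methoxycarbonyl and cyano behaving alike. Running those steps in reverse, a modest rise is expected, a 2.0-fold higher number from compound 3 to compound 4 (0.31 log units; beyond the scatter). Compound 4 is therefore estimated at 11000 nM, with a range from 5500 nM to 22000 nM.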

Compound 4, half-maximal cytotoxic concentration: 15200 nM
Compound 4: the middle estimate sits 1.4-fold (0.14 log units) below what was measured; the measured number falls inside the stated range.
By their numbers in this assay, from the lowest: compound 3; then compounds 1, 4 and 2 (each within the scatter of the next).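

With the ring held constant, methoxycarbonyl in place of fluoro gives a clear change (a 2.8-fold higher number from compound 3 to compound 4 (0.45 log units; beyond the scatter)), so the low number of compound 3 goes with the fluoro and not with the carbon-only ring. Exchanging the ring leaves the number unmoved, both against the 6-(methoxycarbonyl)pyridin-2-yl group (a 1.0-fold higher number from compound 1 to compound 4 (0.02 log units; within the scatter)) and against the 6-cyanopyridin-2-yl group (a 1.0-fold lower number from compound 2 to compound 4 (0.01 log units; within the scatter)). No measurement at hand accounts for the fluoro result.

Still open, going by these compounds, is whether an amine or a carboxylic acid at this place would match compound 4 or compound 3.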